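This account rests on a few compounds, and the source may have more. Where it says the series, first, only, none or still open, it means among the compounds named here.

Measured in a functional assay on SW-620 cells (Homo sapiens) for cytotoxicity, read by colorimetric assay; a lower number here means a stronger inhibitor, a higher number a weaker inhibitor:
compound 1 `O=C(NO)c1ccc(CN2C(=O)/C(=C3\Nc4ccccc4\C3=N/O)c3cc(Cl)ccc32)cc1`: 60 nM
compound 2 `O=C(NO)c1ccc(CN2C(=O)/C(=C3\Nc4ccccc4\C3=N/O)c3cc(F)ccc32)cc1`: 20 nM

Of these two, compound 2 holds the lower number, at 20 nM. The swap of chloro for fluoro on an aromatic carbon gives a 3.0-fold lower number from compound 1 to compound 2 (0.48 log units; beyond the scatter), a modest step beyond the scatter.

The next compound, compound 3 `O=C(/C=C/c1ccc(CN2C(=O)/C(=C3\Nc4ccccc4\C3=N/O)c3cc(F)ccc32)cc1)NO`, keeps the fluoro and the shared core but differs at the other end of the molecule: 2-(hydroxycarbamoyl)ethenyl in place of hydroxycarbamoyl on an aromatic carbon. Among the compounds with values here, no measured compound carries the 2-(hydroxycarbamoyl)ethenyl group, so the data hold no direct precedent for this change. Within the data shown here, the single measured step, a 3.0-fold lower number from compound 1 to compound 2 (0.48 log units; beyond the scatter), concerns the halogen and not the hydroxycarbamoyl group. It offers only a rough sense of how far a single change has moved the number in this assay, and it gives no direction. A step beyond the scatter is therefore not expected with any confidence. The expected step is small: a 1.3-fold lower number from compound 2 to compound 3 (0.10 log units; within the scatter). For compound 3 the estimated value is 16 nM, with an expected range from 5 nM to 60 nM.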

Compound 3, half-maximal inhibitory concentration: 50 nM
Estimate against measurement, compound 3: 3.1-fold (0.49 log units) below; measured number inside the range.
By their numbers in this assay, from the lowest: compound 2; then compounds 3 and 1 (each within the scatter of the next).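

In this assay, putting 2-(hydroxycarbamoyl)ethenyl in place of hydroxycarbamoyl on the aromatic carbon para to a large group gives a 2.5-fold higher number from compound 2 to compound 3 (0.40 log units; beyond the scatter). This shows that the number responds to a change at this end of the molecule as well as to the halogen swap, and that lengthening the group at this position with fluoro kept moves the number upward. The hydrogen-bond donor and acceptor counts stay the same and neither group carries a net charge, so the change lies in the added carbon atoms and the extra double bond, but no measurement at hand bears on why the number rises.

The compounds shown leave open whether the step depends on the double bond or on the added length, which a saturated 2-(hydroxycarbamoyl)ethyl group would help to separate, and whether a carboxylic acid could stand in place of the hydroxycarbamoyl group at this position. They also leave open whether the same change would give a step of similar size with chloro in place of fluoro on the shared core.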